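The source may report more compounds than this note shows. Statements on the series, on what has been measured and on what is new or still open speak of the compounds shown alone.

Compound 1 `CN1CCN(CCCn2cccc2/C=N/NC(=O)Nc2ccc(Oc3ccnc4[nH]ccc34)c(F)c2)CC1`: 2740 nM
Compound 2 `O=C(N/N=C/c1cccn1CCCN1CCCCC1)Nc1ccc(Oc2ccnc3[nH]ccc23)cc1`: 3690 nM

Both values come from a functional assay on HepG2 cells (Homo sapiens) for antiproliferative activity, read by MTT assay, with a stated time of 72 h; a higher number here means a weaker inhibitor, a lower number a stronger inhibitor. Compound 2, at 3690 nM, cannot be told apart from compound 1, at 2740 nM. The two lie within the usual scatter of repeated measurements. Compound 3 `CN1CCN(CCCn2cccc2/C=N/NC(=O)Nc2ccc(Oc3ccnc4[nH]ccc34)cc2)CC1` has 4-methylpiperazin-1-yl in place of piperidin-1-yl on a saturated chain carbon, three bonds along the chain from an aromatic nitrogen. Compound 1 also carries 4-methylpiperazin-1-yl and gives 2740 nM, so no step beyond the scatter is expected in this assay. The expected step is a 1.2-fold lower number from compound 2 to compound 3 (0.09 log units; within the scatter). For compound 3 the estimated value is 3000 nM, with an expected range from 1200 nM to 7500 nM.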

Compound 3, half-maximal inhibitory concentration: 2760 nM
Compound 3: middle estimate off by 1.1-fold (0.04 log units), on the high side, within the range that was stated.
By their numbers in this assay, from the lowest: compounds 1, 3 and 2 (each within the scatter of the next).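

In this assay, 4-methylpiperazin-1-yl in place of piperidin-1-yl on a saturated chain carbon, three bonds along the chain from an aromatic nitrogen, gives a 1.3-fold lower number from compound 2 to compound 3 (0.13 log units; within the scatter). Hydrogen in place of fluoro on an aromatic carbon gives a 1.0-fold higher number from compound 1 to compound 3 (0.00 log units; within the scatter), so neither change separates the compounds it connects in this assay. Nothing measured here offers an explanation for these results.

Still open, from the compounds shown here alone, is whether morpholine or a dimethylamino group in place of 4-methylpiperazin-1-yl would move the number beyond the scatter. The same question applies to a longer chain than the propyl chain of 3-(4-methylpiperazin-1-yl)propyl.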